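Ethoxy in place of fluoro on the benzylidene ring

This account rests on a few compounds, and the source may have more. Where it says the series, first, only, none or still open, it means among the compounds named here.

Compound 2 `CC(C)=CCOc1c(C)c(C)c2c(c1C)CCC(C)(COc1ccc(/C=C3\SC(=O)NC3=O)cc1F)O2` stands highest of the three numbers in a functional assay on MCF7 cells (Homo sapiens), tested at 2.5 uM (on this read-out lower numbers stand for a stronger effect and higher numbers for a weaker effect at the one concentration tested), where compound 2 gives 95%. Compound 3 `Cc1c(C)c2c(c(C)c1OC/C=C/c1ccccc1)CCC(C)(COc1ccc(/C=C3\SC(=O)NC3=O)cc1)O2` gives 92%, within the scatter of compound 2, while compound 1 `C=CCOc1c(C)c(C)c2c(c1C)CCC(C)(COc1ccc(/C=C3\SC(=O)NC3=O)cc1)O2` gives 45%. Compound 4 `CCOc1cc(/C=C2\SC(=O)NC2=O)ccc1OCC1(C)CCc2c(C)c(OCC=C(C)C)c(C)c(C)c2O1` differs from compound 2 by ethoxy in place of fluoro on an aromatic carbon. Among the measured compounds shown here, the one measured step, a number 47 percentage points higher from compound 1 to compound 3 (beyond the scatter), changes a different part of the molecule and bears only loosely on this change; no measured pair isolates the fluoro itself. He therefore expects no step beyond the scatter, a number 5 percentage points lower from compound 2 to compound 4 (within the scatter), in this assay. Compound 4 is estimated at 90%, between 65% and 105%.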

Compound 4, a percentage reported as activity, at one concentration (the size of the read-out at that concentration, not a potency): 107%
Compound 4: the middle estimate sits 17 percentage points below what was measured, and the stated range ends below it.
By their numbers in this assay, from the lowest: compound 1; then compounds 3 and 2 (each within the scatter of the next); then compound 4.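

In this assay, ethoxy in place of fluoro on an aromatic carbon ortho to a large group gives a number 12 percentage points higher from compound 2 to compound 4 (beyond the scatter) as the first step read at this position. The change therefore runs towards a weaker effect at the one concentration tested, whereas the earlier step concerned only the other end of the molecule. Nothing at hand accounts for this step.

The compounds shown leave open how methoxy or an amine on this carbon would read. They also leave open whether ethoxy would give a like step on the core of compound 1, or how fluoro compares with hydrogen here.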